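The compounds below may be only part of what the source reports. "The series", "measured", "known", "first", "only" and "open" are said of these compounds alone.

Among the compounds with values here, compound 3 `CN(C)C(=O)CCNC(=O)c1cc(-c2ccccc2F)no1` is one of three compounds measured in an ADME assay on microsomes from liver (Homo sapiens) for metabolic stability, with a stated time of 0.5 h, tested at 0.5 mg/mL; a higher number here means that more of the compound is left, a lower number that less of the compound is left. Compound 3 gives > 100%, which is a limit of the assay rather than a number. Compound 2 `CN(C)C(=O)CCNC(=O)c1cc(-c2cccc(F)c2)no1` likewise gives > 100%, again a limit. Compound 1 `CN(C)C(=O)CCNC(=O)c1csc(-c2ccc(F)cc2)n1`, built on a different core, gives 53%. Within the data shown here, the only step between measured compounds that differ in one place, a step that the two limits leave unreadable from compound 2 to compound 3, cannot be read because both of its ends sit at the limit of > 100% in this assay, at which 2 of the 3 values shown sit. Compound 4 `CN(C)C(=O)CCNC(=O)c1cc(-c2ccccc2)no1` differs from compound 3 by hydrogen in place of fluoro on an aromatic carbon. Among the measured compounds shown here, no measured step shows how this change acts on the numbers: the one step in this assay is unreadable, and compound 1 differs from compound 4 in the core as well as in its fluoro. Compound 3 stands at a limit, so even an unchanged outcome would give no readable step. The account therefore expects the step of a number at least 10 percentage points lower from compound 3 to compound 4 (that floor lies within the scatter) to be no larger than the scatter. Compound 4 is estimated at 90%, with a range from 60% to 100%.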

Compound 4, percent of the compound remaining: 81%
The estimate for compound 4 lay 9 percentage points above the measured number; measured number inside the range.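

In this assay, hydrogen in place of fluoro on an aromatic carbon now has a readable outcome: it gives a number at least 19 percentage points lower from compound 3 to compound 4 (beyond the scatter), and the same exchange gives a number at least 19 percentage points lower from compound 2 to compound 4 (beyond the scatter). Within the data shown here, the earlier compounds could not show this, since the one step among them was unreadable; now the 2-fluorophenyl and the 3-fluorophenyl compounds each stand apart from the phenyl compound 4 beyond the scatter. Each size is only a floor, since neither fluoro compound gives a number: the limit of > 100% in this assay, at which 2 of the 4 values shown sit.

How far compound 2 and compound 3 truly stand from compound 4, and whether they differ from each other, cannot be read. Going by these compounds, whether a chloro or a methyl group on the phenyl ring would go with the same outcome as fluoro also remains open.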